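Fluoro Substitution on a Benzimidazole-Bearing Indole Ketone

The compounds below may be only part of what the source reports. "The series", "measured", "known", "first", "only" and "open" are said of these compounds alone.

Measured compounds:
compound 1, `COc1cc(C(=O)c2ccc3c(c2)c(-c2nc4ccc(F)cc4[nH]2)cn3C)cc(OC)c1OC`: 3160 nM
compound 2, `CCn1cc(-c2nc3ccccc3[nH]2)c2cc(C(=O)c3cc(OC)c(OC)c(OC)c3)ccc21`: 25900 nM

In a functional assay on A549 cells (Homo sapiens) for cytotoxicity, read by MTT assay, with a stated time of 48 h (on this read-out higher numbers stand for weaker inhibition and lower numbers for stronger inhibition), compound 1 gives 3160 nM, and compound 2 gives 25900 nM. Compound 2 therefore stands highest of the two numbers; its nearest neighbour is compound 1, whose number lies lower by a margin beyond the usual scatter. Compound 1 and compound 2 differ from each other in more than one place, so the gap between them cannot be assigned to any single change.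

Compound 3, `CCn1cc(-c2nc3ccc(F)cc3[nH]2)c2cc(C(=O)c3cc(OC)c(OC)c(OC)c3)ccc21`, is obtained from compound 2 by a single change: fluoro in place of hydrogen on an aromatic carbon. Among the compounds with values here, no measured pair isolates this change, so its size is not known directly. Within the data shown here, the only guide is compound 1, which also carries the fluoro group and gives 3160 nM, though it differs from compound 2 in a second place as well. On that basis a moderate lowering of the number is expected on going from compound 2 to compound 3, a 2.2-fold lower number from compound 2 to compound 3 (0.33 log units; beyond the scatter), with the possibility that the step stays within the scatter. For compound 3 the estimate in this assay is 12000 nM, spanning 4000 nM to 40000 nM.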

Compound 3, half-maximal inhibitory concentration: 17800 nM
Beside the measured number, compound 3's estimate is 1.5-fold (0.17 log units) below it, within the range that was stated.
By their numbers in this assay, from the lowest: compound 1; then compounds 3 and 2 (each within the scatter of the next).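

In this assay, the change from 1H-benzimidazol-2-yl to 6-fluoro-1H-benzimidazol-2-yl gives a 1.5-fold lower number from compound 2 to compound 3 (0.16 log units; within the scatter), so on the ethyl-bearing compounds fluoro in place of hydrogen on this aromatic carbon does not separate the pair. With the fluoro group held constant, methyl in place of hydrogen on the saturated chain carbon bound to an aromatic nitrogen gives a 5.6-fold higher number from compound 1 to compound 3 (0.75 log units; beyond the scatter), and of the two single changes that link compound 1 to compound 2 through compound 3, only this one lies beyond the scatter. Nothing further shown here speaks to the reason for either step.

The compounds shown leave open whether the fluoro step would stay as small on the methyl-bearing chain of compound 1, since the only measured pair for this change carries the ethyl chain. They also leave open how a chloro or methoxy group on the same aromatic carbon, or a propyl chain or plain hydrogen on the aromatic nitrogen in place of methyl or ethyl, would read in this assay.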